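The source may report more compounds than this note shows. Statements on the series, on what has been measured and on what is new or still open speak of the compounds shown alone.

Values in a functional assay on MDA-MB-231 cells (Homo sapiens) for antiproliferative activity, read by sulforhodamine B assay, with a stated time of 72 h; a higher number here means a weaker inhibitor, a lower number a stronger inhibitor:
- Compound 1 `O=C(/C=C/c1csc2ccccc12)c1ccccc1O`: 5300 nM
- Compound 2 `O=C(/C=C/c1csc2ccccc12)c1cc(Br)ccc1O`: 840 nM
- Compound 3 `COc1ccc(O)c(C(=O)/C=C/c2csc3ccccc23)c1`: 760 nM

Compound 3 shares the low end of these numbers: a 1.1-fold lower number from compound 2 to compound 3 (0.04 log units; within the scatter), whereas a 7.0-fold lower number from compound 1 to compound 3 (0.84 log units; beyond the scatter). Compound 4 `CCOc1ccc(O)c(C(=O)/C=C/c2csc3ccccc23)c1` turns methoxy into ethoxy, with methyl in place of hydrogen on a saturated chain carbon bound to an oxygen on an aromatic ring. Among the measured compounds shown here, no measured step lengthens a chain, so the evidence is indirect. Adding a group to the bare core mattered, as in a 6.3-fold lower number from compound 1 to compound 2 (0.80 log units; beyond the scatter), but exchanging one added group for another did not, as in a 1.1-fold lower number from compound 2 to compound 3 (0.04 log units; within the scatter). A small extension should therefore change little in this assay. The expected change is a 1.0-fold lower number from compound 3 to compound 4 (0.01 log units; within the scatter), with no direction favoured and nothing expected beyond the scatter. Compound 4 is estimated at 750 nM, with an expected range of 330 nM to 1700 nM.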

Compound 4, half-maximal inhibitory concentration: 6700 nM
Estimate against measurement, compound 4: 8.9-fold (0.95 log units) below; measured number above the stated range.
By their numbers in this assay, from the lowest: compounds 3 and 2 (each within the scatter of the next); then compounds 1 and 4 (each within the scatter of the next).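

Lengthening methoxy to ethoxy by a single methyl costs much of the activity at this position (an 8.8-fold higher number from compound 3 to compound 4 (0.95 log units; beyond the scatter)), so here a small extension is not a neutral change. Unlike the earlier swap of bromo for methoxy, which made no real difference, ethoxy also separates from bromo (an 8.0-fold higher number from compound 2 to compound 4 (0.90 log units; beyond the scatter)) and keeps none of the gain over the unsubstituted compound (a 1.3-fold higher number from compound 1 to compound 4 (0.10 log units; within the scatter)). No measurement here accounts for this sharp sensitivity.

As far as these compounds go, whether a longer chain such as propoxy would weaken activity further stays open. So does whether a hydroxy or an amine on this aromatic carbon would match methoxy.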